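The compounds below may be only part of what the source reports. "The series", "measured", "known", "first", "only" and "open" are said of these compounds alone.

For the measured compounds named here, compound 1, with the structure `COc1cccc(OC(c2ccc(C(F)(F)F)cc2)C2CCN(C(C)CCNC(=O)c3c(Cl)cncc3Cl)CC2)n1`, is the weaker-tolerated of the two compounds measured so far. In an ADME assay on PBMC cells (Homo sapiens) for cytotoxicity (a higher number here means that more compound is tolerated, a lower number that less compound is tolerated), compound 1 gives 32700 nM, the lowest of the two numbers. Compound 2, with the structure `CC(CCNC(=O)c1c(Cl)cncc1Cl)N1CCC(C(=O)c2ccc(Br)cc2)CC1`, gives in this assay a value of 189000 nM, a higher number that lies beyond the usual scatter of this assay. Going by the values given here, the two compounds differ in more than one place, so no single-change step can be drawn between them.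

Compound 3, with the structure `COC(=O)c1cccc(OC(c2ccc(C(F)(F)F)cc2)C2CCN(C(C)CCNC(=O)c3c(Cl)cncc3Cl)CC2)n1`, has not yet been tested in this assay. It differs from compound 1 in one place: methoxycarbonyl in place of methoxy on an aromatic carbon. Nothing in the measured data speaks to this kind of exchange, so the expected step of a 1.1-fold lower number from compound 1 to compound 3 (0.04 log units; within the scatter) is small and not clearly distinguished from the scatter. Compound 3 is therefore estimated to give 30000 nM in this assay, with a plausible range from 12000 nM to 80000 nM.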

Compound 3, half-maximal cytotoxic concentration: 14600 nM
The estimate for compound 3 lay 2.1-fold (0.31 log units) above the measured number; low and high end bracket the measured number.
By their numbers in this assay, from the lowest: compound 3; then compound 1; then compound 2.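

For the compounds shown here, at this position, on an aromatic carbon next to the ring nitrogen, the exchange of methoxy for methoxycarbonyl gives the first single-change step in this assay: a 2.2-fold lower number from compound 1 to compound 3 (0.35 log units; beyond the scatter). The position is therefore not indifferent to what it carries: with the rest of the molecule unchanged, methoxycarbonyl goes with less compound tolerated than methoxy, though the step is modest. Nothing measured here bears on the reason for this step.

As far as these compounds go, it remains open whether this step is specific to methoxycarbonyl or would recur with a carboxylic acid, a primary amide or a nitrile on the same carbon. Also open, from the compounds shown here alone, is how a plain hydrogen or a longer alkoxy chain at this place would compare with the methoxy of compound 1.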